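A few compounds are considered here, and "the series" means these few. Any claim that something is new, unique, unknown or untested is made for them only; others in the source may bear on it.

Of the compounds shown here, three built on a shared core have been tested in an assay on isolated protein for inhibition of DNA topoisomerase 1 (Homo sapiens), with a stated time of 15 min; a lower number here means a stronger inhibitor, a higher number a weaker inhibitor. Compound 1 `COc1c(N2CC[C@@H](N)C2)c(F)cc2c(=O)c(C(=O)O)cn(Cc3ccc(-c4ccccc4)cc3)c12` gives 92200 nM there. Compound 2 `CNCCNc1cc2c(cc1F)c(=O)c(C(=O)O)cn2Cc1ccc(-c2ccccc2)cc1` reaches only a limit of this assay, recorded as > 200000 nM. Compound 3 `CNCCNc1c(F)cc2c(=O)c(C(=O)O)cn(Cc3ccc(-c4ccccc4)cc3)c2c1OC` also reaches only a limit, recorded as > 200000 nM. Compound 2 therefore stands at the limit of > 200000 nM in this assay, at which 2 of the 3 values shown sit, so no number is known for it, only that it is a weak inhibitor.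

The unmeasured compound 4 `O=C(O)c1cn(Cc2ccc(-c3ccccc3)cc2)c2cc(N3C[C@H]4CCNC[C@H]4C3)c(F)cc2c1=O` differs from compound 2 in one place: a group of 9 heavy atoms (7 carbon, 2 nitrogen; one five-membered non-aromatic ring with 1 hetero atom, one six-membered non-aromatic ring with 1 hetero atom) in place of a group of 5 heavy atoms (3 carbon, 2 nitrogen; no ring), on an aromatic carbon.

For the measured compounds named here, two measured steps bear on this change. The step of an at least 2.1-fold higher number from compound 1 to compound 3 (0.33 log units; beyond the scatter) swapped a ring amine for the same open-chain amine that leaves here, and the number rose. The step that the two limits leave unreadable from compound 2 to compound 3 cannot be sized, since both ends are limits. Going by the values given here, the change to compound 4 runs the first step in reverse, putting a ring amine back in place of the chain, so a lower number is expected. Yet compound 1 shows that a ring amine on this core still gives a weak 92200 nM.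

Compound 4 is therefore expected to give about 80000 nM, within a range of 30000 nM to 200000 nM. This estimate amounts to a step of an at least 2.5-fold lower number from compound 2 to compound 4 (0.39 log units; beyond the scatter), expected to fall toward stronger inhibition.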

Compound 4, half-maximal inhibitory concentration: 61000 nM
Estimate against measurement, compound 4: 1.3-fold (0.12 log units) above, and the stated range covers the measured number.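

In this assay, the fused two-ring amine in place of (2-(methylamino)ethyl)amino gives an at least 3.2-fold lower number from compound 2 to compound 4 (0.51 log units; beyond the scatter), so a ring amine can bring a compound off the limit even with hydrogen, not methoxy, on the neighbouring part of the shared core. This is the same direction as the earlier chain-for-ring step read in reverse, so in both readable pairs the ring amine gives the lower number, and no compound shown goes against this, though the two ring amines differ and the gain remains small in absolute terms, with compound 4 still at 61000 nM. The value of compound 2 is a limit and not a number, so the step has a lower bound and no exact size: the limit of > 200000 nM in this assay, at which 2 of the 4 values shown sit.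

The step between the two open-chain compounds cannot be read, since both ends are limits, which leaves open what methoxy in place of hydrogen does at this carbon of the core. As far as these compounds go, it also remains open whether the lower number needs both fused rings or whether a single ring, such as piperazine, or a longer chain ending in a primary amine, would give the same result.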